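From benzyl to a fluorinated aryl carbonyl

A few compounds are considered here, and "the series" means these few. Any claim that something is new, unique, unknown or untested is made for them only; others in the source may bear on it.

Measured so far in a functional assay on MDA-MB-231 cells (Homo sapiens) for antiproliferative activity, read by MTT assay, with a stated time of 72 h; a lower number here means a stronger inhibitor, a higher number a weaker inhibitor:
compound 1 `CC(=O)O[C@H]1CC[C@]2(C)[C@H](CC[C@@](C)(O)[C@H]2CC[C@@H]2C(C)=CC[C@H]3[C@H](CC[C@]3(C)O)C2(C)C)OC1(C)C`: 38000 nM
compound 2 `CC1=CC[C@H]2[C@H](CC[C@]2(C)O)C(C)(C)[C@@H]1CC[C@H]1[C@]2(C)CC[C@H](OC(=O)c3ccc(Cl)cc3)C(C)(C)O[C@H]2CC[C@@]1(C)O`: 10300 nM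
compound 3 `CC1=CC[C@H]2[C@H](CC[C@]2(C)O)C(C)(C)[C@@H]1CC[C@H]1[C@]2(C)CC[C@H](OCc3ccccc3)C(C)(C)O[C@H]2CC[C@@]1(C)O`: 29100 nM

Two measured steps place compound 3 among these numbers. One stays within the usual scatter (a 1.3-fold lower number from compound 1 to compound 3 (0.12 log units; within the scatter)) and the other goes beyond it (a 2.8-fold higher number from compound 2 to compound 3 (0.45 log units; beyond the scatter)). The next compound to be tested is compound 4 `CC1=CC[C@H]2[C@H](CC[C@]2(C)O)C(C)(C)[C@@H]1CC[C@H]1[C@]2(C)CC[C@H](OC(=O)c3ccc(F)cc3)C(C)(C)O[C@H]2CC[C@@]1(C)O`, which carries (4-fluorophenyl)carbonyl in place of benzyl on an oxygen on a saturated carbon.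

The closest guide is compound 2, which carries (4-chlorophenyl)carbonyl on that oxygen. The step to benzyl (a 2.8-fold higher number from compound 2 to compound 3 (0.45 log units; beyond the scatter)) suggests that returning to an aryl carbonyl could lower the number. The other aryl carbonyl step (a 3.7-fold lower number from compound 1 to compound 2 (0.57 log units; beyond the scatter)) points the same way. For the measured compounds named here, no fluorinated compound has yet been measured, so this remains an inference from a single close neighbour.

A modest move is therefore expected, estimated as a 2.1-fold lower number from compound 3 to compound 4 (0.32 log units; beyond the scatter) in this assay. For compound 4 the estimated value is 14000 nM, with an expected range from 7000 nM to 28000 nM in this estimate.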

Compound 4, half-maximal inhibitory concentration: 11300 nM
Estimate against measurement, compound 4: 1.2-fold (0.09 log units) above; low and high end bracket the measured number.
By their numbers in this assay, from the lowest: compounds 2 and 4 (each within the scatter of the next); then compounds 3 and 1 (each within the scatter of the next).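

In this assay compound 4 gives a second aryl carbonyl result at this oxygen, with a 2.6-fold lower number from compound 3 to compound 4 (0.41 log units; beyond the scatter) from the benzyl group and a 3.4-fold lower number from compound 1 to compound 4 (0.53 log units; beyond the scatter) from the acetyl group. Both aryl carbonyl compounds therefore lie beyond the scatter of compound 1 and compound 3, and this is no longer a finding resting on compound 2 alone. The change on the aromatic carbon, a 1.1-fold higher number from compound 2 to compound 4 (0.04 log units; within the scatter), shows that fluoro and chloro cannot be told apart in this assay.

No evidence here accounts for the step from benzyl to (4-fluorophenyl)carbonyl. From the compounds shown here alone, that step alters the carbonyl and the fluoro together, so it remains open whether an unsubstituted phenylcarbonyl, or an aryl carbonyl carrying an amine or a carboxylic acid, would hold this level.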